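A few compounds are considered here, and "the series" means these few. Any claim that something is new, unique, unknown or untested is made for them only; others in the source may bear on it.

In an ADME assay on microsomes from liver (Homo sapiens) for metabolic stability, read by LC-MS, using NADPH, with stated times of 5 min and 30 min, tested at 1 uM (on this read-out lower numbers stand for slow clearance and higher numbers for fast clearance), compound 2 `O=C(Nc1ccccc1)c1cnc(NCc2c(F)ccc3c2CCO3)n2cnnc12` gives 14 mL.min-1.g-1, the low end of three numbers, yet all three sit within the usual scatter of one another: compound 3 `CNC(=O)c1ccc(-c2cnc(NCc3c(F)ccc4c3CCO4)c3cn[nH]c(=O)c23)c(C)n1` gives 23 mL.min-1.g-1 and compound 1 `Cc1cc(-c2cnc(NCc3c(F)ccc4c3CCO4)c3cn[nH]c(=O)c23)n(C)n1` gives 24 mL.min-1.g-1. For the measured compounds named here, the one measured step, a 1.0-fold lower number from compound 1 to compound 3 (0.02 log units; within the scatter), exchanged one aromatic group for another on the shared core and moved nothing. Compound 4 `O=C1CC2(CC2)CN1c1cnc(NCc2c(F)ccc3c2CCO3)n2cnnc12` departs from compound 2 by a group of 8 heavy atoms (6 carbon, 1 nitrogen, 1 oxygen; one three-membered non-aromatic ring of carbon only, one five-membered non-aromatic ring with 1 hetero atom) in place of a group of 9 heavy atoms (7 carbon, 1 nitrogen, 1 oxygen; one six-membered aromatic ring of carbon only), on an aromatic carbon. Going by the values given here, no measured step exchanges an aromatic group for a saturated, ring-bearing one at this position, so there is no direct guide; the only step at hand suggests small changes. For compound 4 the expected result in this assay is 14 mL.min-1.g-1, within 6 mL.min-1.g-1 to 35 mL.min-1.g-1, which means an estimated step of no change at the digits printed from compound 2 to compound 4 (within the scatter).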

Compound 4, intrinsic clearance in microsomes: < 3 mL.min-1.g-1
Compound 4 ended at the assay's limit (the forecaster's own chance of this, stated with the estimate: 5%); at least 4.6-fold (0.66 log units) between middle value and limit.
By their numbers in this assay, from the lowest: compounds 2, 3 and 1 (each within the scatter of the next). At a limit, below all of these: compound 4.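

In this assay, the change at this aromatic carbon gives an at least 4.6-fold lower number from compound 2 to compound 4 (0.66 log units; beyond the scatter). The earlier compounds shown here, all within the scatter of one another, showed no such shift, and this one shows that a change at this position can move clearance beyond the scatter. Compound 4 sits at a limit of the assay, not at a number, so the step gives only a minimum size: the limit of < 3 mL.min-1.g-1 in this assay, at which 1 of the 4 values shown sits.

Phenylcarbamoyl leaves with its aromatic ring and its hydrogen-bond donor together, so these compounds cannot separate the two. Also open, as far as these compounds go, is what a simple amine, or the five-membered ring without its three-membered ring, would give at this carbon.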